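Back to methyl on the hydroxy compound

The source may hold more compounds than are shown below. What is called first, only, known or untested is meant among the compounds shown, and "the series" means these compounds.

In a functional assay on MGC-803 cells (Homo sapiens) for inhibition, read by CCK-8 assay, with a stated time of 48 h (on this read-out lower numbers stand for stronger inhibition and higher numbers for weaker inhibition), compound 3 `COc1ccc(CN(C(=O)CSC(=S)N2CCN(C(=O)OC(C)(C)C)CC2)c2cc(OC)c(OC)c(OC)c2)cc1O` gives 82 nM, the lowest of the three measured numbers, against compound 2 `COc1ccc(CN(C(=O)CSC(=S)N2CCN(C(=O)OC(C)(C)C)CC2)c2cc(OC)c(OC)c(OC)c2)cc1` at 310 nM and compound 1 `COc1ccc(CN(C(=O)CSC(=S)N2CCN(C)CC2)c2cc(OC)c(OC)c(OC)c2)cc1` at 1280 nM. Compound 4 `COc1ccc(CN(C(=O)CSC(=S)N2CCN(C)CC2)c2cc(OC)c(OC)c(OC)c2)cc1O` keeps the hydroxy group and carries methyl in place of tert-butoxycarbonyl on an amine nitrogen in a ring. The reverse exchange, without the hydroxy group, gave a 4.1-fold lower number from compound 1 to compound 2 (0.62 log units; beyond the scatter). Adding hydroxy gave a 3.8-fold lower number from compound 2 to compound 3 (0.58 log units; beyond the scatter). Among the measured compounds shown here, no measured pair shows whether these two changes add, so that remains an assumption. A modest rise beyond the scatter is therefore expected in this assay, an estimated 4.0-fold higher number from compound 3 to compound 4 (0.60 log units; beyond the scatter). For compound 4 the estimated value is 330 nM, with an expected range of 130 nM to 850 nM.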

Compound 4, half-maximal inhibitory concentration: 860 nM
Compound 4: the middle estimate sits 2.6-fold (0.42 log units) below what was measured; the measured number lies above the stated range.
By their numbers in this assay, from the lowest: compound 3; then compound 2; then compounds 4 and 1 (each within the scatter of the next).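

With the hydroxy group present, methyl in place of tert-butoxycarbonyl on the amine nitrogen in the ring gives a large loss, a 10-fold higher number from compound 3 to compound 4 (1.02 log units; beyond the scatter). Among the compounds shown here, with methyl on that nitrogen, hydroxy in place of hydrogen no longer separates the pair, a 1.5-fold lower number from compound 1 to compound 4 (0.17 log units; within the scatter), so a clear hydroxy gain appears only in the tert-butoxycarbonyl compounds. Even so, the two sizes of the nitrogen exchange cannot be told apart, and any interaction between the changes remains unproven: the same change on two cores in this assay, a 4.1-fold lower number (0.62 log units; beyond the scatter) from compound 1 to compound 2 and a 10-fold lower number (1.02 log units; beyond the scatter) from compound 4 to compound 3, 2.5-fold (0.40 log units) apart, within the scatter of two such steps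

Open, going by these compounds, is whether the lower numbers require tert-butoxycarbonyl itself, or whether acetyl or a longer alkyl chain on this nitrogen would also give them.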